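The source may report more compounds than this note shows. Statements on the series, on what has been measured and on what is new or still open speak of the compounds shown alone.

Two analogues share the core of compound 1 `C[C@@H](NC(=O)[C@H](CCCNC(=N)N)NC(=O)c1ccc(CN(Cc2ccc(F)cc2)Cc2ccccn2)cc1)c1cccc2ccccc12`. In an assay on Jurkat cells for displacement of a labelled ligand from C-X-C chemokine receptor type 4 (Homo sapiens), tested at 10 uM (on this read-out lower numbers stand for less inhibition and higher numbers for more inhibition at the one concentration tested (going by the name of the read-out)), compound 1 gives 0%, and compound 2 `C[C@@H](NC(=O)[C@H](CCCNC(=N)N)NC(=O)c1ccc(CN(Cc2ccc(F)cc2)Cc2cccnc2)cc1)c1cccc2ccccc12` gives 6%. Compound 2 holds the higher of the two numbers, though the step of a number 6 percentage points higher from compound 1 to compound 2 (within the scatter) is within the scatter. Compound 3 `C[C@@H](NC(=O)[C@H](CCCNC(=N)N)NC(=O)c1ccc(CN(Cc2ccncc2)Cc2ccc(F)cc2)cc1)c1cccc2ccccc12` differs from compound 2 by pyridin-4-yl in place of pyridin-3-yl on a saturated chain carbon bound to an amine nitrogen. Going by the values given here, the only step that bears on this is a number 6 percentage points higher from compound 1 to compound 2 (within the scatter), which stayed within the scatter, so in this assay no step beyond the scatter is expected for compound 3 either. Compound 3 is therefore estimated at 6%, in the range -6% to 20%, a step of no change at the digits printed from compound 2 to compound 3 (within the scatter) expected to lie within the scatter.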

Compound 3, a percentage reported as inhibition, at one concentration (the size of the read-out at that concentration, not a potency): 12%
Beside the measured number, compound 3's estimate is 6 percentage points below it; low and high end bracket the measured number.
By their numbers in this assay, from the lowest: compounds 1, 2 and 3 (each within the scatter of the next, the first and the last beyond it).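

Going by these compounds alone, on the saturated chain carbon bound to an amine nitrogen, pyridin-4-yl in place of pyridin-3-yl gives a step within the scatter (a number 6 percentage points higher from compound 2 to compound 3 (within the scatter)), whereas pyridin-4-yl in place of pyridin-2-yl gives the only step so far beyond it (a number 12 percentage points higher from compound 1 to compound 3 (beyond the scatter)). The pyridine isomer at this place can therefore shift the number in this assay, though modestly, and compound 2 cannot be separated from either of the others. No available evidence accounts for this difference.

On these data alone, whether a ring nitrogen is needed here remains open, as does the effect of a phenyl or piperidin-4-yl group at this place. The single-concentration read-out also leaves potency undefined.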